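Compound 1 to Compound 4: Pyridin-2-yl Gives Way to Phenyl

A few compounds are considered here, and "the series" means these few. Any claim that something is new, unique, unknown or untested is made for them only; others in the source may bear on it.

Measured compounds:
compound 1 `Nc1ccccc1NC(=O)c1ccc(CSC(=S)N2CCN(Cc3ccccn3)CC2)cc1`: 14.2%
compound 2 `Nc1ccccc1NC(=O)c1ccc(CSC(=S)N2CCc3ccc([N+](=O)[O-])cc32)cc1`: 45.7%
compound 3 `Nc1ccccc1NC(=O)c1ccc(CSC(=S)N2CCCc3ccccc32)cc1`: 26.1%

All three were tested in a functional assay on HeLa cells (Homo sapiens) for antiproliferative activity, read by CCK-8 assay, with a stated time of 72 h, tested at 2 uM; a lower number here means a weaker effect, a higher number a stronger effect of the compound at the concentration tested. Compound 1 gives the lowest of the three numbers; compound 3 lies higher by a margin beyond the usual scatter, and compound 2 higher still, also beyond the scatter. Compound 4 `Nc1ccccc1NC(=O)c1ccc(CSC(=S)N2CCN(Cc3ccccc3)CC2)cc1` has not yet been measured. It differs from compound 1 in a single place: phenyl in place of pyridin-2-yl on a saturated chain carbon bound to an amine nitrogen in a ring. Within the data shown here, no pair of measured compounds shows what such a change does on this core, so the expectation rests only on compound 1 with its 14.2%. A step of a number 3.8 percentage points higher from compound 1 to compound 4 (within the scatter) is expected, small and within the scatter. Compound 4 is therefore estimated at 18%, in a range from 8% to 30%.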

Compound 4, a percentage reported as inhibition, at one concentration (the size of the read-out at that concentration, not a potency): 20.6%
For compound 4 the middle estimate is 2.6 percentage points below the measured one; the range from low to high includes it.
By their numbers in this assay, from the lowest: compounds 1, 4 and 3 (each within the scatter of the next, the first and the last beyond it); then compound 2.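

In this assay, among these compounds, phenyl in place of pyridin-2-yl on this saturated chain carbon gives a number 6.4 percentage points higher from compound 1 to compound 4 (within the scatter) and is the first direct reading of this change on the shared core. At this single concentration, the ring nitrogen with its hydrogen-bond acceptor can therefore go without a difference that stands out from the scatter. Nothing at hand explains this result.

Still open, going by these compounds, is what a cyclohexyl ring or a longer chain would do in place of benzyl. Also open, on these data alone, is whether an amine or a carboxylic acid on the phenyl ring would move the number beyond the scatter.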